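Solubility of an indole amide series: a phenyl swap

The source may report more compounds than this note shows. Statements on the series, on what has been measured and on what is new or still open speak of the compounds shown alone.

Measured compounds in a physicochemical assay for solubility, read by spectrophotometry, in phosphate buffer, with a stated time of 2 h, at pH 7.4; a higher number here means a more soluble compound, a lower number a less soluble compound:
- Compound 1 `COc1cccc(CN2C(=O)CN(C(=O)c3cc4cc(OC)ccc4[nH]3)C[C@@H]2COCc2ccccc2)c1` gives 11700 nM.
- Compound 2 `COc1ccc2[nH]c(C(=O)N3CC(=O)N(Cc4ccccc4)[C@@H](COCc4ccccc4)C3)cc2c1` gives 8800 nM.
- Compound 3 `COc1ccc2[nH]c(C(=O)N3CC(=O)N(Cc4ccc[nH]4)[C@@H](Cc4ccccc4)C3)cc2c1` gives 38400 nM.

Compound 1 sits second of the three numbers. Its nearest neighbour is compound 2, reached by removing a methoxy group from an aromatic carbon; that step, a 1.3-fold lower number from compound 1 to compound 2 (0.12 log units; within the scatter), lies within the scatter, so the two compounds cannot be told apart in this assay. Compound 3, which differs from compound 1 in more than one place, gives a higher number, and that gap lies beyond the scatter.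

Compound 4 `COc1cccc(CN2C(=O)CN(C(=O)c3cc4cc(OC)ccc4[nH]3)C[C@@H]2c2ccccc2)c1` is not yet measured. It is reached from compound 1 by the change (phenyl in place of (benzyloxy)methyl on a saturated ring carbon). Going by the values given here, no measured step covers this change: the only step in hand alters an aromatic substituent, not the saturated ring carbon, and it was within the scatter. The comparison with compound 3 mixes two changes and so gives no clean guide. The step of a 1.0-fold higher number from compound 1 to compound 4 (0.01 log units; within the scatter) is therefore expected to stay within the scatter. Compound 4 is expected to give about 12000 nM in this assay, with a range from 5000 nM to 30000 nM.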

Compound 4, solubility: 13600 nM
Compound 4: the middle estimate sits 1.1-fold (0.05 log units) below what was measured, within the range that was stated.
By their numbers in this assay, from the lowest: compounds 2, 1 and 4 (each within the scatter of the next); then compound 3.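

In this assay, going by these compounds alone, the swap to phenyl in place of (benzyloxy)methyl on a saturated ring carbon gives a 1.2-fold higher number from compound 1 to compound 4 (0.07 log units; within the scatter) and is the first step read at this position. The earlier step touched only an aromatic substituent, whereas this one shows that the read-out stays within the scatter when a group of 9 heavy atoms with 1 hydrogen-bond acceptor leaves this ring carbon and a group of 6 heavy atoms with 0 hydrogen-bond acceptors enters, so the two compounds cannot be told apart here. Nothing available explains why the two read alike.

Both groups carry a six-membered aromatic ring of carbon only, so the compounds shown leave open whether a group without such a ring, such as an aminomethyl group or a carboxylic acid, would also stay within the scatter at this ring carbon. They also leave open whether the same swap would read alike with benzyl in place of the 3-methoxybenzyl group.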